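The source may report more compounds than this note shows. Statements on the series, on what has been measured and on what is new or still open speak of the compounds shown alone.

Measured compounds in an assay on isolated protein for inhibition of proto-oncogene tyrosine-protein kinase receptor Ret variant V804M (Homo sapiens), read by radiometric assay and 33P incorporation, in the presence of a further agent that is not named here; on this read-out lower numbers stand for stronger inhibition and higher numbers for weaker inhibition:
compound 1 `Nc1ncnc2c1c(-c1cc(C3CC3)on1)nn2C1CCCCC1` gives 14 nM.
compound 2 `CC(C)c1cc(-c2nn(C(C)C)c3ncnc(N)c23)no1` gives 355 nM.
compound 3 `CC(C)n1nc(-c2ccon2)c2c(N)ncnc21` gives 903 nM.

Compound 1 stands lowest of the three numbers, and both compound 2 and compound 3 lie above it by more than the usual scatter. For the measured compounds named here, the only one-place step measured so far is a 2.5-fold higher number from compound 2 to compound 3 (0.41 log units; beyond the scatter), which concerns the group on the 1,2-oxazole ring and not the substituent on the shared core.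

Compound 4 `Cn1nc(-c2cc(C3CC3)on2)c2c(N)ncnc21` is not yet measured. The change from compound 1 is methyl in place of cyclohexyl on an aromatic nitrogen. Going by the values given here, no measured pair isolates this change: compound 1 and compound 2 differ at the aromatic nitrogen and on the 1,2-oxazole ring at once, so the gap between their values cannot be assigned to either place. What the data show is that the compound carrying cyclohexyl on the aromatic nitrogen holds the lowest number, and that the removal of a carbon group elsewhere in this assay gave a higher number. On that basis compound 4 is expected to give a higher number than compound 1, with the step of a 21-fold higher number from compound 1 to compound 4 (1.33 log units; beyond the scatter) beyond the scatter but uncertain in size. The estimate for compound 4 in this assay is 300 nM, within a range of 60 nM to 1500 nM.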

Compound 4, half-maximal inhibitory concentration: 182 nM
Compound 4: the middle estimate sits 1.6-fold (0.22 log units) above what was measured; the measured number falls inside the stated range.
By their numbers in this assay, from the lowest: compound 1; then compounds 4 and 2 (each within the scatter of the next); then compound 3.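

In this assay, methyl in place of cyclohexyl on the aromatic nitrogen gives a 13-fold higher number from compound 1 to compound 4 (1.11 log units; beyond the scatter). For the compounds shown here, this is the first pair in which this position changes alone, with the 5-cyclopropyl-1,2-oxazol-3-yl group held fixed, so the position can now be read apart from the 1,2-oxazole ring, and the low number of compound 1 goes with cyclohexyl when set against methyl. The reading remains one contrast between two groups and gives no trend with group size; no measurement at hand offers a reason for the step.

Still open, going by these compounds, is whether a cyclopentyl group, a longer chain such as n-butyl, or a cyclohexyl ring carrying an amine or a carboxylic acid would keep the number near that of compound 1 or move it towards that of compound 4. Also open, on these data alone, is whether the same change on the aromatic nitrogen would give a step of similar size with isopropyl or hydrogen in place of cyclopropyl on the 1,2-oxazole ring.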